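The source may hold more compounds than are shown below. What is called first, only, known or untested is meant among the compounds shown, and "the series" means these compounds.

Of the compounds shown here, three built on one shared core have been tested in an assay on RBL-1 cells for inhibition of Polyunsaturated fatty acid 5-lipoxygenase (Rattus norvegicus); a lower number here means a stronger inhibitor, a higher number a weaker inhibitor. Compound 1 `CCc1cccc(N2CCNC(=O)N2)c1` gives 13000 nM in this assay. Compound 2 `COc1cccc(N2CCNC(=O)N2)c1` gives 47000 nM, so placing methoxy in place of ethyl on the aromatic carbon yields a 3.6-fold higher number from compound 1 to compound 2 (0.56 log units; beyond the scatter). Compound 3 `O=C1NCCN(c2cccc(OCc3ccccc3)c2)N1` gives 1100 nM, and placing phenyl on the chain carbon bound to the ring oxygen yields a 43-fold lower number from compound 2 to compound 3 (1.63 log units; beyond the scatter). Compound 2 therefore stands highest of the three numbers, the weakest inhibitor of the set: its nearest neighbour is compound 1, its furthest is compound 3, and both gaps lie beyond the scatter.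

Compound 4 `O=C1NCCN(c2cccc(-c3ccccn3)c2)N1` differs from compound 2 in one place: pyridin-2-yl in place of methoxy on an aromatic carbon. The step that bears most on this change is a 43-fold lower number from compound 2 to compound 3 (1.63 log units; beyond the scatter), where a ring was also added at this position, though there it hung from an oxygen rather than sitting directly on the aromatic carbon. The step of a 3.6-fold higher number from compound 1 to compound 2 (0.56 log units; beyond the scatter) is smaller and points the other way. A clear lowering of the number is therefore expected, though its size is uncertain. Compound 4 is expected to give 3000 nM, with an estimated range from 700 nM to 13000 nM. The expected step is a 16-fold lower number from compound 2 to compound 4 (1.19 log units; beyond the scatter).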

Compound 4, half-maximal inhibitory concentration: 30000 nM
Beside the measured number, compound 4's estimate is 10-fold (1.00 log units) below it; measured number above the stated range.
By their numbers in this assay, from the lowest: compound 3; then compound 1; then compounds 4 and 2 (each within the scatter of the next).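

In this assay, pyridin-2-yl in place of methoxy on the aromatic carbon gives a 1.6-fold lower number from compound 2 to compound 4 (0.19 log units; within the scatter) and so leaves compound 2 and compound 4 indistinguishable, even though a whole six-membered aromatic ring has replaced a small group. Pyridin-2-yl in place of ethyl gives a 2.3-fold higher number from compound 1 to compound 4 (0.36 log units; beyond the scatter) as a modest step, and compound 4 gives 30000 nM while compound 3, whose ring hangs from an oxygen through a chain carbon, gives 1100 nM in this same test, so a ring at this position does not by itself bring the low number. No measurement at hand explains why these two ring-bearing compounds differ.

From the compounds shown here alone, whether a phenyl set directly on this aromatic carbon would match pyridin-2-yl or compound 3 stays open, so the separate parts played by the ring nitrogen and by the oxygen and chain carbon link remain unsorted. How a longer chain ending in a ring, or an amine, would fare at this position is also unknown.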